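Will compound 3 stay at the limit?

The source may hold more compounds than are shown below. What is called first, only, known or untested is meant among the compounds shown, and "the series" means these compounds.

Compound 1 `COc1ccc(-c2nc(COc3cccc(Cl)c3)nc3ccsc23)cn1` and compound 2 `COc1ccc(-c2nc(CCc3cccc(Cl)c3)nc3ccsc23)cn1` share one core and were both tested in an ADME assay on cells (Homo sapiens) for cytotoxicity, read by resazurin assay, with a stated time of 5 days; on this read-out higher numbers stand for lower toxicity in this test and lower numbers for higher toxicity in this test. Compound 1 gives > 50000 nM, which is a limit of the test and not a number. Compound 2 gives > 50000 nM, which is again only a limit. Compound 2 therefore has no exact value, and the whole record so far is the limit of > 50000 nM in this assay, at which 2 of the 2 values shown sit.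

Compound 3 `COc1ccc(-c2nc(CSc3cccc(Cl)c3Cl)nc3ccsc23)cn1` carries (2,3-dichlorophenyl)sulfanyl in place of 3-chlorobenzyl on a saturated chain carbon bound to an aromatic carbon. Within the data shown here, the only measured step at this place is a step that the two limits leave unreadable from compound 1 to compound 2, so it offers no size to build on. Neither measured compound shows a number under the limit, so no step beyond the usual scatter is expected, in either direction. The expected change is a number no higher from compound 2 to compound 3 (the limit leaves the size open), and this estimate is tentative. For compound 3 the estimate is 50000 nM, with an expected range from 20000 nM to 100000 nM, and a report of only a limit is the likeliest outcome.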

Compound 3, half-maximal cytotoxic concentration: > 50000 nM
Compound 3: a limit, no number; the forecaster's own chance of this, stated with the estimate: 75%; the middle value sits exactly at the limit.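

In this assay compound 3 gives > 50000 nM, which is a limit of the test and not a number. No step among compound 1, compound 2 and compound 3 can therefore be read: the limit of > 50000 nM in this assay, at which 3 of the 3 values shown sit.

The compounds shown leave open how far apart these three actually lie, and whether any change at this place would give a number under the limit.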